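Dropping the carboxy group from a biaryl ether modulator

The source may hold more compounds than are shown below. What is called first, only, known or untested is meant among the compounds shown, and "the series" means these compounds.

Of the compounds shown here, three have been measured in an assay on HEK293 cells for positive allosteric modulation of metabotropic glutamate receptor 2 (Rattus norvegicus), read by thallium flux; on this read-out higher numbers stand for an effect only at larger amounts of compound and lower numbers for an effect already at smaller amounts. Compound 1 `O=C(O)c1cc(-c2cccc(COc3ccc4c(=O)n(C5CC5)sc4c3)c2)ccc1Cl` gives 130 nM in this assay, compound 2 `Cc1ccc(C(=O)O)cc1-c1cccc(COc2ccc3c(c2)CN(C2CCCC2)C3=O)c1` gives 110 nM, and compound 3 `O=C(O)c1cc(-c2cccc(COc3ccc4c(=O)n(C5CCCC5)sc4c3)c2)ccc1F` gives 240 nM. Compound 2 sits alongside compound 1 within the usual scatter, while compound 3 lies beyond the scatter at a higher number, so compound 2 belongs to the more potent pair of the three.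

Compound 4 `O=C1c2ccc(OCc3cccc(-c4ccccc4)c3)cc2CN1C1CCCC1` has not been measured. It differs from compound 2 in one place: phenyl in place of 5-carboxy-2-methylphenyl on an aromatic carbon. The group that leaves carries the one hydrogen-bond donor and the one hydrogen-bond acceptor counted for it; what enters carries none. No measured pair among these three shares this change, so no measured step tells its size directly. All three measured compounds keep a carboxy group on the outer ring, and all three give numbers in a narrow band. The expectation for compound 4 in this assay is therefore a step upward beyond the scatter, with the estimated step being an 18-fold higher number from compound 2 to compound 4 (1.26 log units; beyond the scatter). In this assay compound 4 is expected at about 2000 nM, with a range from 400 nM to 10000 nM.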

Compound 4, half-maximal effective concentration: > 5000 nM
Compound 4: no number, only a limit; the forecaster's own chance of this, stated with the estimate: 25%; middle value at least 2.5-fold (0.39 log units) from the limit.
By their numbers in this assay, from the lowest: compounds 2, 1 and 3 (each within the scatter of the next, the first and the last beyond it). At a limit, above all of these: compound 4.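

In this assay, putting phenyl in place of 5-carboxy-2-methylphenyl on this aromatic carbon produces an at least 45-fold higher number from compound 2 to compound 4 (1.65 log units; beyond the scatter), the first step measured at this position and a large one. The earlier compounds shown here all kept a carboxy group on the outer ring and so could not show what happens without one; compound 4 shows that, on the core of compound 2, the bare phenyl does not retain a comparable number. The result for compound 4 is a limit and not a number, so the step marks only the smallest size the change can have, and its full size stays unknown: the limit of > 5000 nM in this assay, at which 1 of the 4 values shown sits.

The change removes the carboxy group and the methyl group together, so the compounds shown cannot tell how much of the step belongs to either one. They also leave open whether a phenyl carrying only the carboxylic acid, or one carrying a tetrazole or a primary amide in its place, would stay near compound 2 or fall with compound 4.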